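The compounds below may be only part of what the source reports. "The series", "measured", "known", "first", "only" and "open" are said of these compounds alone.

Compound 1 `Cc1cccc(-n2cc(-c3cccc(NS(=O)(=O)c4c[nH]c(=O)[nH]c4=O)c3)nn2)c1`: in an ADME assay on L02 cells (Homo sapiens) for cytotoxicity, read by MTT assay, with a stated time of 24 h (a higher number here means that more compound is tolerated, a lower number that less compound is tolerated), compound 1 gives 28300 nM
Compound 2 `Cc1ccc(-n2cc(-c3cccc(NS(=O)(=O)c4c[nH]c(=O)[nH]c4=O)c3)nn2)cc1`: in this assay compound 2 gives 23100 nM
Compound 3 `O=c1[nH]cc(S(=O)(=O)Nc2cccc(-c3cn(-c4ccccc4F)nn3)c2)c(=O)[nH]1`: in this assay compound 3 is reported as "not toxic" (no number reported)

Of the compounds shown here, three sharing one core have been tested for how much of each liver cell line tolerates. Compound 1 and compound 2 differ only in where a methyl group sits on the phenyl attached to an aromatic nitrogen, and that move gives a 1.2-fold lower number from compound 1 to compound 2 (0.09 log units; within the scatter). Compound 3 carries a 2-fluorophenyl in the same place, and for it no number was reported in this assay, only the word that it was not toxic.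

Compound 4 `O=c1[nH]cc(S(=O)(=O)Nc2cccc(-c3cn(-c4cccc(F)c4)nn3)c2)c(=O)[nH]1` is the untested partner of compound 3. The change is 3-fluorophenyl in place of 2-fluorophenyl on an aromatic nitrogen. Among the measured compounds shown here, the one measured step that resembles it, a methyl moved around the same phenyl from compound 1 to compound 2, stayed within the scatter, so a move of fluorine around that phenyl is expected to change this assay little, if at all. Compound 3 has no number to start from, which leaves the estimate loose, anchored loosely on the numbers of compound 1 and compound 2 and on the non-toxic report for compound 3. Compound 4 is therefore expected to give about 60000 nM, with a plausible range from 20000 nM to 200000 nM.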

Compound 4, half-maximal cytotoxic concentration: "not toxic" (no number reported)
The entry for compound 4 holds no number, so the estimate cannot be set against anything.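

Compound 3 and compound 4 are both reported in this assay only as "not toxic", with no number, so no step can be read between them. Nothing available here accounts for this result. The compounds shown leave open how much of either compound the cells tolerate, and whether moving the fluorine around the phenyl changes that.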